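Amino Acid Ester in Place of Acetate: Expected Gain

This account rests on a few compounds, and the source may have more. Where it says the series, first, only, none or still open, it means among the compounds named here.

Of the compounds shown here, three sharing one core have been tested in a functional assay on HCT-116 cells (Homo sapiens) for inhibition, read by fluorescence, with a stated time of 48 h; on this read-out lower numbers stand for stronger inhibition of growth and higher numbers for weaker inhibition of growth. Compound 2 `CC(=O)OCCCOC1(c2ccc(Cl)cc2)c2ccccc2C(=O)N1Cc1ccc(Cl)cc1` gives 46000 nM. Compound 1 `N[C@H](C(=O)OCCCOC1(c2ccc(Cl)cc2)c2ccccc2C(=O)N1Cc1ccc(Cl)cc1)c1ccccc1` gives 12000 nM; the difference between them, (amino(phenyl)methyl in place of methyl on a carbonyl carbon), brings a 3.8-fold lower number from compound 2 to compound 1 (0.58 log units; beyond the scatter). Compound 3 `CC(=O)OCC(C)(C)COC1(c2ccc(Cl)cc2)c2ccccc2C(=O)N1Cc1ccc(Cl)cc1` gives 35000 nM, and its core differs from that of compound 2 by 1-(acetoxymethyl)-1-methylethyl in place of 2-acetoxyethyl on a saturated chain carbon bound to an oxygen on a saturated carbon, giving a 1.3-fold lower number from compound 2 to compound 3 (0.12 log units; within the scatter). Compound 4 `CC(C)(COC(=O)[C@@H](N)c1ccccc1)COC1(c2ccc(Cl)cc2)c2ccccc2C(=O)N1Cc1ccc(Cl)cc1` has not been measured. It differs from compound 3 by amino(phenyl)methyl in place of methyl on a carbonyl carbon, the same change that separates compound 2 and compound 1, at the same place. Because a 3.8-fold lower number from compound 2 to compound 1 (0.58 log units; beyond the scatter) was modest yet beyond the scatter, a step of similar size is expected here, estimated as a 3.7-fold lower number from compound 3 to compound 4 (0.57 log units; beyond the scatter). Compound 4 is therefore expected to give about 9500 nM in this assay, most likely between 3000 nM and 30000 nM.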

Compound 4, concentration for 50% growth inhibition: 8000 nM
The estimate for compound 4 lay 1.2-fold (0.07 log units) above the measured number, within the range that was stated.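

In this assay, amino(phenyl)methyl in place of methyl on the carbonyl carbon gives a 4.4-fold lower number from compound 3 to compound 4 (0.64 log units; beyond the scatter). This change carried over from one core to the other with much the same size: the same change on two cores in this assay, a 3.8-fold lower number (0.58 log units; beyond the scatter) from compound 2 to compound 1 and a 4.4-fold lower number (0.64 log units; beyond the scatter) from compound 3 to compound 4, 1.1-fold (0.06 log units) apart, within the scatter of two such steps. That agreement rests on only these two closely related cores and this one assay, so it does not show that the step would hold on a different core, and it does not explain why the numbers fall.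

The compounds shown leave open whether a simple aminomethyl group on the same carbonyl carbon, without the aromatic ring, would give a step of similar size. They also leave open how the opposite arrangement at the defined stereocentre would read.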